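This account rests on a few compounds, and the source may have more. Where it says the series, first, only, none or still open, it means among the compounds named here.

Measured in a functional assay on Bel7402/5-FU cells (Homo sapiens) for antiproliferative activity, read by MTT assay, with a stated time of 72 h; a lower number here means a stronger inhibitor, a higher number a weaker inhibitor:
- compound 1 `C=C1C(=O)O[C@H]2[C@H]1CC/C(COC(=O)Cn1cc(F)c(=O)n(Cc3ccccc3)c1=O)=C\CC[C@@]1(C)O[C@@H]21`: 4270 nM
- compound 2 `C=C1C(=O)O[C@H]2[C@H]1CC/C(COC(=O)Cn1cc(F)c(=O)n(Cc3ccc(Cl)cc3)c1=O)=C\CC[C@@]1(C)O[C@@H]21`: 2420 nM
- compound 3 `C=C1C(=O)O[C@H]2[C@H]1CC/C(COC(=O)Cn1cc(F)c(=O)n(Cc3ccc([N+](=O)[O-])cc3)c1=O)=C\CC[C@@]1(C)O[C@@H]21`: 4340 nM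

Compound 3, at 4340 nM, lies within the scatter of both other compounds. Compound 4 `C=C1C(=O)O[C@H]2[C@H]1CC/C(COC(=O)Cn1cc(F)c(=O)n(Cc3ccc(F)c(F)c3)c1=O)=C\CC[C@@]1(C)O[C@@H]21` differs from it as follows: 3,4-difluorophenyl in place of 4-nitrophenyl on a saturated chain carbon bound to an aromatic nitrogen. The measured steps on this aromatic ring are a 1.8-fold lower number from compound 1 to compound 2 (0.25 log units; within the scatter), a 1.0-fold higher number from compound 1 to compound 3 (0.01 log units; within the scatter) and a 1.8-fold higher number from compound 2 to compound 3 (0.25 log units; within the scatter), and none leaves the scatter. Going by the values given here, no measured compound carries a 3,4-difluorophenyl group, so the support is indirect. On those three steps, no change beyond the scatter is expected in this assay. The estimated step is a 1.3-fold lower number from compound 3 to compound 4 (0.12 log units; within the scatter). For compound 4 the expected value is 3300 nM, with an estimated range of 1700 nM to 6500 nM.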

Compound 4, half-maximal inhibitory concentration: 4480 nM
Compound 4: the middle estimate sits 1.4-fold (0.13 log units) below what was measured; low and high end bracket the measured number.
By their numbers in this assay, from the lowest: compounds 2, 1, 3 and 4 (each within the scatter of the next).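

In this assay, 3,4-difluorophenyl on a saturated chain carbon bound to an aromatic nitrogen gives a 1.0-fold higher number from compound 3 to compound 4 (0.01 log units; within the scatter) against 4-nitrophenyl, a 1.9-fold higher number from compound 2 to compound 4 (0.27 log units; within the scatter) against 4-chlorophenyl and a 1.0-fold higher number from compound 1 to compound 4 (0.02 log units; within the scatter) against phenyl. A ring carrying two fluorines therefore joins the unsubstituted, chloro and nitro rings, with no step among these four compounds leaving the scatter. Nothing available accounts for how closely these values agree.

Open, from the compounds shown here alone, is whether an amine or a carboxylic acid on the aromatic ring would leave the number within the scatter. Also open, going by these compounds, is whether a longer chain in place of the benzyl link would do so.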